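Trifluoromethyl on a Second Core: Carrying One Step Across

This account rests on a few compounds, and the source may have more. Where it says the series, first, only, none or still open, it means among the compounds named here.

Measured compounds:
Compound 1 `C=C(C)C(=O)c1ccc(OCc2nc(-c3ccccc3)no2)c(C)c1C` gives 1800 nM in an assay on HL-60 cells for inhibition of glutathione S-transferase P (Homo sapiens); a higher number here means a weaker inhibitor, a lower number a stronger inhibitor.
Compound 2 `C=C(C)C(=O)c1ccc(OCc2nc(-c3ccc(C(F)(F)F)cc3)no2)c(C)c1C` gives 3900 nM in this assay.
Compound 3 `C=C(C)C(=O)c1ccc(OCc2nc(-c3ccccc3)no2)cc1Cl` gives 600 nM in this assay.

Compound 1 and compound 2 share a core and differ in a single place: trifluoromethyl in place of hydrogen on an aromatic carbon. In this assay this change produces a 2.2-fold higher number from compound 1 to compound 2 (0.34 log units; beyond the scatter), so the trifluoromethyl compound gives the higher number, that is, the weaker inhibition. Compound 3 is built on a different core; how its core differs from the core of compound 1 is not broken down here. Among the three measured compounds, compound 3 gives the lowest number in this assay, and its gaps to compound 1 and to compound 2 both lie beyond the usual scatter.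

Compound 4 `C=C(C)C(=O)c1ccc(OCc2nc(-c3ccc(C(F)(F)F)cc3)no2)cc1Cl` has not yet been measured. It relates to compound 3 exactly as compound 2 relates to compound 1: trifluoromethyl in place of hydrogen on an aromatic carbon. The place of the change is described in the same words for both pairs, so this is the same change, now made on the core of compound 3. Within the data shown here, the only guide to what it will do is the pair already measured, because a 2.2-fold higher number from compound 1 to compound 2 (0.34 log units; beyond the scatter) shows the size of step this change made once before. For compound 4 the expected step in this assay is therefore a 2.2-fold higher number from compound 3 to compound 4 (0.34 log units; beyond the scatter), a step of about the same size. Compound 4 is estimated at 1300 nM. The lower end of the estimate for compound 4 is 600 nM. The upper end of the estimate for compound 4 is 2800 nM.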

Compound 4, half-maximal inhibitory concentration: 700 nM
Beside the measured number, compound 4's estimate is 1.9-fold (0.27 log units) above it; low and high end bracket the measured number.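

In this assay, the same change on the second core gives a 1.2-fold higher number from compound 3 to compound 4 (0.07 log units; within the scatter), a step too small to be told apart from the ordinary spread of repeated measurements. Set beside the earlier pair, the two steps do not differ by more than the scatter allows, so the result on the second core does not stand apart from the result on the first: the same change on two cores in this assay, a 2.2-fold higher number (0.34 log units; beyond the scatter) from compound 1 to compound 2 and a 1.2-fold higher number (0.07 log units; within the scatter) from compound 3 to compound 4, 1.9-fold (0.27 log units) apart, within the scatter of two such steps. This shows that the earlier step was a fair guide to the second core, but it does not show that the two cores respond alike, as one step lies beyond the scatter and the other within it, and two pairs of compounds are too few to make a rule for the series.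

The compounds shown leave open whether other groups at the same place, such as a nitrile, a methoxy group or a carboxylic acid, would make steps of similar size on both cores. They also leave open whether trifluoromethyl would make a step of this size on a third core, or at another place on the same aromatic ring.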